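This account rests on a few compounds, and the source may have more. Where it says the series, first, only, none or still open, it means among the compounds named here.

Of the compounds shown here, three built on one shared core have been measured in a functional assay on SW-620 cells (Homo sapiens) for inhibition, read by sulforhodamine B assay, with a stated time of 48 h, tested at 0.1 uM; on this read-out higher numbers stand for a weaker effect at the one concentration tested and lower numbers for a stronger effect. Compound 1 `O=C(Nc1cccc(-n2cc(-c3ccncc3)c(-c3cc(O)cc(Cl)c3)n2)c1)Nc1ccc(Cl)c(Cl)c1` gives 99% in this assay. Compound 2 `COc1cc(Cl)cc(-c2nn(-c3cccc(NC(=O)Nc4ccc(Cl)c(C(F)(F)F)c4)c3)cc2-c2ccncc2)c1` gives 96%, and compound 3 `COc1cc(Cl)cc(-c2nn(-c3cccc(NC(=O)Nc4ccc(Cl)c(Cl)c4)c3)cc2-c2ccncc2)c1` gives 97%. On these numbers compound 3 sits between the other two, yet all three lie within the scatter of one another, so none of them can be called stronger or weaker at the single concentration tested. The two steps that lead to compound 3 say the same: a number 2 percentage points lower from compound 1 to compound 3 (within the scatter), and a number 1 percentage points higher from compound 2 to compound 3 (within the scatter).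

Compound 4 `COc1cc(Cl)cc(-c2nn(-c3cccc(NC(=O)c4cccc(C(F)(F)F)c4)c3)cc2-c2ccncc2)c1` has not yet been measured. It differs from compound 3 by 3-(trifluoromethyl)phenyl in place of (3,4-dichlorophenyl)amino on a carbonyl carbon. Neither measured step touches this part of the molecule; both altered other groups, and both stayed within the scatter. Among the measured compounds shown here, no measured step therefore bears directly on the present change, and the only guide is that every measured compound sits near the top of the read-out in this assay. The expected step is no change at the digits printed from compound 3 to compound 4 (within the scatter), which means no movement beyond the scatter is anticipated. Compound 4 is estimated to give 97% in this assay, with a range from 88% to 104%.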

Compound 4, a percentage reported as activity, at one concentration (the size of the read-out at that concentration, not a potency): 99%
For compound 4 the middle estimate is 2 percentage points below the measured one; the range from low to high includes it.
By their numbers in this assay, from the lowest: compounds 2, 3, 1 and 4 (each within the scatter of the next).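

Among the compounds shown here, this is the first look at the carbonyl carbon itself. The earlier steps shown here changed other places on the molecule. Replacing (3,4-dichlorophenyl)amino with 3-(trifluoromethyl)phenyl removes a group that carries a hydrogen-bond donor and brings in one that carries none, yet in this assay the result is a number 2 percentage points higher from compound 3 to compound 4 (within the scatter) and the number stays close to where it was. The same holds when the group that leaves is (4-chloro-3-(trifluoromethyl)phenyl)amino, with a number 3 percentage points higher from compound 2 to compound 4 (within the scatter) as the printed step, so this large change at the carbonyl carbon shows no effect beyond the scatter on either of the two compounds compared. No measurement at hand offers an explanation for this result.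

On these data alone, with a single concentration and numbers this close together, it remains open whether these compounds would separate from one another at other concentrations. As far as these compounds go, it is also open whether a quite different group on the same carbonyl carbon, such as a simple amine, a carboxylic acid or a longer chain, would move the number beyond the scatter.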